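Replacing the fluoro group of compound 2 with hydrogen

A few compounds are considered here, and "the series" means these few. Any claim that something is new, unique, unknown or untested is made for them only; others in the source may bear on it.

Measured in a functional assay on SW480 cells (Homo sapiens) for antiproliferative activity, read by MTT assay, with a stated time of 48 h; a higher number here means a weaker inhibitor, a lower number a stronger inhibitor:
- compound 1 `CCCC(CCO)n1cnc2c(Cl)ncnc21`: > 50000 nM
- compound 2 `CCCCCCCC(CCO)n1cnc2c(Cl)nc(F)nc21`: 26100 nM

Compound 1 gives > 50000 nM, which is a limit of the assay and not a number. For the measured compounds named here, compound 2, at 26100 nM, therefore holds the only actual number so far.

Compound 3 `CCCCCCCC(CCO)n1cnc2c(Cl)ncnc21` has not yet been measured. It differs from compound 2 by hydrogen in place of fluoro on an aromatic carbon, between two ring nitrogen atoms and meta to a chloro group. Going by the values given here, no measured pair isolates this change, so the direction is open and no step beyond the usual scatter is expected in this assay. The estimated step is a 1.1-fold higher number from compound 2 to compound 3 (0.06 log units; within the scatter), which is expected to stay within that scatter. For compound 3 the estimate is 30000 nM, with an expected range of 12000 nM to 55000 nM.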

Compound 3, half-maximal inhibitory concentration: 3630 nM
Beside the measured number, compound 3's estimate is 8.3-fold (0.92 log units) above it, outside the stated range (below it).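

In this assay, hydrogen in place of fluoro on an aromatic carbon, between two ring nitrogen atoms, gives a 7.2-fold lower number from compound 2 to compound 3 (0.86 log units; beyond the scatter), so this position responds to the change and compound 3 carries the lowest actual number in the series. Butyl in place of hydrogen on a saturated chain carbon, four bonds along the chain from an aromatic nitrogen, gives an at least 13-fold lower number from compound 1 to compound 3 (1.13 log units; beyond the scatter), which shows that the chain also matters on the shared core. The size of that second step stays a lower bound, as compound 1 gives only a limit of the assay and not a number: the limit of > 50000 nM in this assay, at which 1 of the 3 values shown sits.

As far as these compounds go, whether an amine or a methoxy group at the fluoro position would keep the number as low as hydrogen does remains open. Also open, from the compounds shown here alone, is whether a longer chain would lower the number further or reverse the direction.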